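From Hydroxyamidine to Guanidine: Expected Oral Exposure

The source may report more compounds than this note shows. Statements on the series, on what has been measured and on what is new or still open speak of the compounds shown alone.

Two compounds have been run through an ADME assay on the whole organism (strain Sprague-Dawley) for pharmacokinetics, with Rattus norvegicus as the target, read by LC-MS, at a dose of 50 mg/kg by the oral route; on this read-out higher numbers stand for higher oral bioavailability and lower numbers for lower oral bioavailability. Compound 1 `CCC(CC)O[C@@H]1C=C(C(=O)O)C[C@H](NC(C)=N)[C@H]1NC(C)=O` gives 3.9% in this assay, while compound 2 `CCOC(=O)C1=C[C@@H](OC(CC)CC)[C@H](NC(C)=O)[C@@H](N/C(C)=N/O)C1` gives 31.4%, the higher of the two numbers, and the gap between them lies beyond the scatter. Compound 3 `CCOC(=O)C1=C[C@@H](OC(CC)CC)[C@H](NC(C)=O)[C@@H](NC(=N)N)C1` has not yet been measured. The change from compound 2 to compound 3 is a group of 3 heavy atoms (1 carbon, 2 nitrogen; no ring) in place of a group of 4 heavy atoms (2 carbon, 1 nitrogen, 1 oxygen; no ring), on an amine nitrogen and nothing more. Going by the values given here, no step between measured compounds that differ in one place exists to guide the expectation. A downward step a number 21.4 percentage points lower from compound 2 to compound 3 (beyond the scatter) beyond the scatter is expected. The estimate for compound 3 is 10%, within a range from 2% to 28%.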

Compound 3, oral bioavailability in the Rattus norvegicus assay: 1.3%
Compound 3: middle estimate off by 8.7 percentage points, on the high side; the measured number lies below the stated range.
By their numbers in the Rattus norvegicus assay, from the lowest: compounds 3 and 1 (each within the scatter of the next); then compound 2.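

In the Rattus norvegicus assay, placing the group of 3 heavy atoms on the amine nitrogen in place of the group of 4 gives a number 30.1 percentage points lower from compound 2 to compound 3 (beyond the scatter), the first one-place step seen at this position. In a physicochemical assay for solubility, read by HPLC, in phosphate buffer, with a stated time of 20 min, at pH 7.4 (a higher number here means a more soluble compound, a lower number a less soluble compound), compound 2 gives 23000000 nM, and the same change brings an at least 2.1-fold higher number from compound 2 to compound 3 (0.33 log units; beyond the scatter), so the two read-outs move in opposite directions here. In the physicochemical assay compound 3 gives > 50000000 nM, which is a limit of the assay and not a number: the limit of > 50000000 nM in the physicochemical assay, at which 1 of the 2 values shown sits.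

The compounds shown leave open how an acetyl group or a longer chain on this amine nitrogen would read in the Rattus norvegicus assay. They also cannot tell what lies behind the fall.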